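Acetamido to benzylamino: notes on compound 3

This account rests on a few compounds, and the source may have more. Where it says the series, first, only, none or still open, it means among the compounds named here.

Within the data shown here, in a functional assay on NCI-H460 cells (Homo sapiens) for cytotoxicity (on this read-out higher numbers stand for weaker inhibition and lower numbers for stronger inhibition), compound 1 (`COc1ccc(S(=O)(=O)N2CCc3cccc(NC(=O)c4cccs4)c32)cc1`) gives 49 nM and compound 2 (`COc1ccc(S(=O)(=O)N2CCc3cccc(NC(C)=O)c32)cc1`) gives 75 nM as the second of only two numbers, and the pair lies within the scatter. Compound 3 (`COc1ccc(S(=O)(=O)N2CCc3cccc(NCc4ccccc4)c32)cc1`) carries benzyl in place of acetyl on a nitrogen on an aromatic ring. Among the measured compounds shown here, the only measured step (a 1.5-fold higher number from compound 1 to compound 2 (0.18 log units; within the scatter)) stays within the scatter, but it keeps the carbonyl, so it bears only partly on this change. In this assay the estimated step is a 2.0-fold higher number from compound 2 to compound 3 (0.30 log units; within the scatter) and its size is uncertain. The estimate for compound 3 is 150 nM (expected range 30 nM to 800 nM).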

Compound 3, half-maximal inhibitory concentration: > 10000 nM
Compound 3: only a limit was reported; the forecaster's own chance of this, stated with the estimate: 5%; middle value at least 66-fold (1.82 log units) away from the limit.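

The earlier pair, which both keep a carbonyl on this nitrogen, lay within the scatter of each other, so this position had looked permissive; benzyl in place of acetyl gives an at least 130-fold higher number from compound 2 to compound 3 (2.12 log units; beyond the scatter), and benzyl in place of (thiophen-2-yl)carbonyl gives an at least 200-fold higher number from compound 1 to compound 3 (2.30 log units; beyond the scatter). Activity in this assay therefore depends strongly on the group at this nitrogen, and compound 1 shows that an aromatic ring carried through a carbonyl is compatible with it. Compound 3 gives only a limit, not a number: the limit of > 10000 nM in this assay, at which 1 of the 3 values shown sits.

The compounds shown do not separate loss of the carbonyl from the entry of the benzyl group. A benzoyl group would keep the carbonyl with the same ring, and a plain ethyl group would lack both.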